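The compounds below may be only part of what the source reports. "The series", "measured", "known", "first", "only" and "open" are said of these compounds alone.

Measured compounds:

Compound 1 `CC(C)c1cccc(C(C)C)c1OC(=O)NS(=O)(=O)N1CCCCC1`: in an assay on liver for inhibition of sterol O-acyltransferase 1 (Rattus norvegicus), using microsomes (on this read-out lower numbers stand for stronger inhibition and higher numbers for weaker inhibition), compound 1 gives > 100000 nM, which is a limit of the assay and not a number.

Compound 2 `CCCCCCCCCCCCOS(=O)(=O)NC(=O)Oc1c(C(C)C)cccc1C(C)C`: in this assay compound 2 gives 13000 nM.

For the measured compounds named here, compound 2 therefore stands as the only actual number in this small set. Going by the values given here, the other entry, that of compound 1, sits at the limit of > 100000 nM in this assay, at which 1 of the 2 values shown sits, so no step between two measured numbers can be drawn, and nothing is known about how far a change of this kind moves the read-out.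

Compound 3 `CCCCCCCCCCCCCCCCOS(=O)(=O)NC(=O)Oc1c(C(C)C)cccc1C(C)C` has not yet been measured. It differs from compound 2 by butyl in place of hydrogen on a saturated chain carbon, ten or more bonds along the chain from an oxygen on an unsaturated carbon; the core carrying the carbamate and the sulfamate link is the same in both.

Among the compounds with values here, with no measured step to lean on, the expectation rests on compound 2 alone. A change from compound 2 to compound 3 of a 1.6-fold lower number from compound 2 to compound 3 (0.21 log units; within the scatter) is expected, a step toward somewhat stronger inhibition but not far beyond the usual scatter. On that basis compound 3 is estimated at 8000 nM, with a range from 2000 nM to 40000 nM.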

Compound 3, half-maximal inhibitory concentration: 10300 nM
Beside the measured number, compound 3's estimate is 1.3-fold (0.11 log units) below it; low and high end bracket the measured number.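

In this assay, the first step measured at this position is a 1.3-fold lower number from compound 2 to compound 3 (0.10 log units; within the scatter), for butyl in place of hydrogen on a saturated chain carbon, ten or more bonds along the chain from an oxygen on an unsaturated carbon. The earlier compounds shown here offered no such step, and this one shows that, at this far end of the chain, adding these four carbons leaves the two compounds indistinguishable on this read-out, with the shared core unchanged. No measurement shown bears on why the chain change has so little effect on the read-out.

A single step within the scatter cannot show whether the read-out would stay just as flat with a shorter chain or a longer chain at this position. It also leaves open whether a polar end group, such as an amine or a carboxylic acid placed at the far end of the chain, would move the number any further than butyl does.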